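The source may hold more compounds than are shown below. What is called first, only, known or untested is meant among the compounds shown, and "the series" means these compounds.

Working notes on the series. Of the compounds shown here, two have been measured in an assay on BaF3 cells with thrombopoietin receptor (Homo sapiens) as the target, read by a luciferase reporter; on this read-out higher numbers stand for larger maximal responses and lower numbers for smaller maximal responses. Compound 1 `O=S(=O)(O)c1cc(O)c(/N=C/c2c(O)ccc3ccccc23)c2ccccc12` links a sulfonated naphthol to a second naphthol through an imine. In this assay compound 1 reaches only a limit of the assay, < 5%. Compound 2 `Cc1[nH]n(C(C)(C)C)c(=O)c1/N=N/c1c(O)cc(S(=O)(=O)O)c2ccccc12` links the sulfonated naphthol through an azo bridge to a five-membered ring that carries a methyl and a tert-butyl group. In this assay compound 2 also reaches only a limit of the assay, < 5%. Compound 2 therefore stands at the floor of the numbers recorded so far, since (the limit of < 5% in this assay, at which 2 of the 2 values shown sit). Going by the values given here, no pair of measured compounds differs in one place, so no measured step shows how any change on this core moves the maximal response.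

Compound 3 `Cc1[nH]n(-c2cc(Cl)c(S(=O)(=O)O)cc2Cl)c(=O)c1/N=N/c1c(O)cc(S(=O)(=O)O)c2ccccc12` is the next compound to be measured. It differs from compound 2 in this way: a group of 12 heavy atoms (6 carbon, 3 oxygen, 1 sulfur, 2 chlorine; one six-membered aromatic ring of carbon only) in place of a group of 4 heavy atoms (4 carbon; no ring), on an aromatic nitrogen. Nothing measured speaks for or against this replacement. For compound 3 the expected maximal response in this assay is 6%, within 0% to 25%. The expected step is a number at least 1 percentage points higher from compound 2 to compound 3 (that floor lies within the scatter), that is no movement beyond the scatter, because every value recorded so far sits at the limit (the limit of < 5% in this assay, at which 2 of the 2 values shown sit).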

Compound 3, largest response reached (reported as efficacy), in percent of the reference or control that the assay uses: < 5%
Compound 3: a limit, no number (the forecaster's own chance of this, stated with the estimate: 70%); at least 1 percentage points between middle value and limit.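

The step between compound 2 and compound 3 cannot be read, since both compounds sit at a limit of this assay and neither gives a number: the limit of < 5% in this assay, at which 3 of the 3 values shown sit.

The compounds shown leave open whether any change on this core can lift the maximal response off that limit.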